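A few compounds are considered here, and "the series" means these few. Any claim that something is new, unique, unknown or untested is made for them only; others in the source may bear on it.

Of the compounds shown here, three built on one shared core have been measured in an ADME assay on MT4 cells (Homo sapiens) for cytotoxicity, read by MTT assay, with a stated time of 5 days; on this read-out lower numbers stand for higher toxicity in this test and higher numbers for lower toxicity in this test. Compound 1 `COc1ccc(-c2cnc(Nc3ccc(C#N)cc3)nc2Oc2c(C)cc(C#N)cc2C)cc1` is recorded only as a limit of the assay, > 279000 nM. Compound 2 `Cc1cc(C)cc(-c2cnc(Nc3ccc(C#N)cc3)nc2Oc2c(C)cc(C#N)cc2C)c1` gives 39000 nM. Compound 3 `Cc1cc(C#N)cc(C)c1Oc1nc(Nc2ccc(C#N)cc2)ncc1-c1ccc(N)cc1` gives 310 nM, the lowest of the two actual numbers, and the gap to the nearest neighbour is wide: a 130-fold lower number from compound 2 to compound 3 (2.10 log units; beyond the scatter). Compound 4 `Cc1cc(C#N)cc(C)c1Oc1nc(Nc2ccc(C#N)cc2)ncc1-c1cccs1` has not yet been measured. The change leading to it is thiophen-2-yl in place of 4-aminophenyl on an aromatic carbon. For the measured compounds named here, two measured steps bear on this change. In the step of a 130-fold lower number from compound 2 to compound 3 (2.10 log units; beyond the scatter) the 4-aminophenyl group enters, and in the step of an at least 900-fold lower number from compound 1 to compound 3 (2.95 log units; beyond the scatter) an amino group takes the place of methoxy; both are large drops in the number, so the 4-aminophenyl group of compound 3 goes along with its low value. Taking that group away for thiophen-2-yl is expected to move the number back up, by roughly a 97-fold higher number from compound 3 to compound 4 (1.99 log units; beyond the scatter). Compound 4 is estimated at 30000 nM, within a range from 5000 nM to 200000 nM.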

Compound 4, half-maximal cytotoxic concentration: 6430 nM
Estimate against measurement, compound 4: 4.7-fold (0.67 log units) above, within the range that was stated.
By their numbers in this assay, from the lowest: compound 3; then compound 4; then compound 2. At a limit, above all of these: compound 1.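

In this assay, putting thiophen-2-yl on this carbon in place of 4-aminophenyl gives a 21-fold higher number from compound 3 to compound 4 (1.32 log units; beyond the scatter), so the very low number of compound 3 does not carry over to every aromatic ring at this position. The rise stops short of the phenyl compounds, though: with a 6.1-fold lower number from compound 2 to compound 4 (0.78 log units; beyond the scatter), the five-membered ring still reads clearly lower than 3,5-dimethylphenyl. The remaining comparison, an at least 43-fold lower number from compound 1 to compound 4 (1.63 log units; beyond the scatter), rests on the value of compound 1, which is only a limit, so its true size stays unknown: the limit of > 279000 nM in this assay, at which 1 of the 4 values shown sits.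

The compounds shown leave open where a plain phenyl ring or a furan-2-yl group would fall at this position. A 4-hydroxyphenyl group would also help to show whether the low number of compound 3 goes with its amino group specifically.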